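Capping a Phenol: Growth Inhibition Before and After

The source may report more compounds than this note shows. Statements on the series, on what has been measured and on what is new or still open speak of the compounds shown alone.

Compound 1 `COc1ccc(/C=C/C2(C)C=CC(=O)O2)c(OC)c1OC` and compound 2 `COc1c(O)ccc(/C=C/C2(C)C=CC(=O)O2)c1OC` share a core and differ only where a hydroxy group becomes methoxy, a change counted as methyl in place of hydrogen on an oxygen on an aromatic ring. In a functional assay on NCI/ADR-RES cells (Homo sapiens) for inhibition, read by sulforhodamine B assay, with a stated time of 48 h (a higher number here means a weaker inhibitor of growth, a lower number a stronger inhibitor of growth), compound 2 gives 51600 nM, while compound 1 gives 349000 nM, so the step of a 6.8-fold higher number from compound 2 to compound 1 (0.83 log units; beyond the scatter) weakens growth inhibition. Compound 3 `CC1(/C=C/c2cccc(O)c2)C=CC(=O)O1` carries a different core; how its core differs from that of compound 2 is not broken down here. In this assay compound 3 gives 647000 nM. Compound 4 `COc1cccc(/C=C/C2(C)C=CC(=O)O2)c1` is derived from compound 3 by the same change, (methyl in place of hydrogen on an oxygen on an aromatic ring). Because the earlier step of a 6.8-fold higher number from compound 2 to compound 1 (0.83 log units; beyond the scatter) weakened inhibition, a step of similar direction, a 3.9-fold higher number from compound 3 to compound 4 (0.59 log units; beyond the scatter), is expected. Compound 4 is therefore estimated at 2500000 nM, likely between 700000 nM and 8000000 nM, though the different core of compound 3 makes the size uncertain.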

Compound 4, concentration for total growth inhibition: 48600 nM
Estimate against measurement, compound 4: 51-fold (1.71 log units) above, and the stated range ends above it.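

Capping the hydroxy group as methoxy did not repeat its earlier effect: in this assay the step is a 13-fold lower number from compound 3 to compound 4 (1.12 log units; beyond the scatter) and growth inhibition strengthens instead of weakening. Set side by side, the two results clearly part, so the direction of this change did not carry from one core to the other: the same change on two cores in this assay, a 6.8-fold higher number (0.83 log units; beyond the scatter) from compound 2 to compound 1 and a 13-fold lower number (1.12 log units; beyond the scatter) from compound 3 to compound 4, 90-fold (1.95 log units) apart, beyond the scatter of two such steps. These pairs show that the same change can go opposite ways on different cores, but they do not show which feature of the cores decides the outcome, and two pairs give no rule for a third core.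

The compounds shown carry only hydroxy or methoxy at the changed place, so it stays open how an ethoxy group or an amine there would behave. Also open, on these data alone, is which way the hydroxy to methoxy change would go on any further core.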